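Notes on a bromo-for-iodo exchange in the series

The source may report more compounds than this note shows. Statements on the series, on what has been measured and on what is new or still open speak of the compounds shown alone.

Values in a functional assay on L929 cells for cytotoxicity against L cells (Mus musculus); on this read-out lower numbers stand for an effect already at smaller amounts and higher numbers for an effect only at larger amounts of compound:
compound 1, `Cc1cn([C@H]2C[C@H](N)[C@@H](CO)O2)c(=O)[nH]c1=O`: 3 uM
compound 2, `N[C@H]1C[C@H](n2ccc(=O)[nH]c2=O)O[C@@H]1CO`: > 100 uM (a limit of this assay, not a number)
compound 3, `NC1CC(n2cc(I)c(=O)[nH]c2=O)OC1CO`: > 100 uM (a limit of this assay, not a number)

Compound 3 stands at the limit of > 100 uM in this assay, at which 2 of the 3 values shown sit, so no number is known for it. The unmeasured compound 4, `NC1CC(n2cc(Br)c(=O)[nH]c2=O)OC1CO`, differs from compound 3 by bromo in place of iodo on an aromatic carbon. Among the measured compounds shown here, the one measured step, an at least 33-fold higher number from compound 1 to compound 2 (1.52 log units; beyond the scatter), concerns hydrogen in place of methyl and not an exchange of one halogen for another; it therefore offers no direct guide to the size of the present change. For the measured compounds named here, with no step of the same kind in hand, the change is taken as one that should stay within the usual scatter, and compound 4 is expected to sit at or near the same limit as compound 3. The estimate for compound 4 in this assay is 100 uM, with a range from 30 uM to 300 uM, and the step of a number no higher from compound 3 to compound 4 (the limit leaves the size open) is expected to be none beyond the scatter.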

Compound 4, concentration for half-maximal effect: > 100 uM
Compound 4: only a limit was reported; the forecaster's own chance of this, stated with the estimate: 70%; the middle value lies on the limit itself.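

In this assay compound 4 gives > 100 uM, a limit and not a number. Compound 3 also sits at a limit, so no step can be read between compound 3 and compound 4. Going by these compounds, whether bromo in place of iodo alters the read-out at all remains open.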